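Thiosemicarbazone series: ring substitution and imine methyl

A few compounds are considered here, and "the series" means these few. Any claim that something is new, unique, unknown or untested is made for them only; others in the source may bear on it.

Measured compounds:
compound 1 `CC1=CC[C@@H]([C@@](C)(O)CCCC(C)(C)NC(=S)N/N=C\c2ccccc2Cl)CC1`: 42000 nM
compound 2 `CC1=CC[C@@H]([C@@](C)(O)CCCC(C)(C)NC(=S)N/N=C\c2cccc(Cl)c2)CC1`: 8270 nM

Compound 2 gives the lowest number of the two in a functional assay on OVCAR-3 cells (Homo sapiens) for cytotoxicity, read by sulforhodamine B assay; on this read-out higher numbers stand for weaker inhibition of growth and lower numbers for stronger inhibition of growth; compound 1 sits above it by a 5.1-fold lower number from compound 1 to compound 2 (0.71 log units; beyond the scatter), a step beyond the scatter. Among the compounds with values here, only this one step has been measured, and it concerns where the chlorine sits on the ring, not whether a chlorine is there at all.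

Compound 3 `CC1=CC[C@@H]([C@@](C)(O)CCCC(C)(C)NC(=S)N/N=C(/C)c2ccccc2)CC1` is yet to be measured in this assay. It differs from compound 2 by a group of 9 heavy atoms (8 carbon, 1 nitrogen; one six-membered aromatic ring of carbon only) in place of a group of 9 heavy atoms (7 carbon, 1 nitrogen, 1 chlorine; one six-membered aromatic ring of carbon only), on an amide-type nitrogen: the chlorine is gone and a methyl group now sits on the carbon with the double bond to nitrogen. Neither part of this change is covered by a measured step, so the step from compound 1 to compound 2 says little about it beyond showing that changes on this side of the molecule can move the number beyond the scatter. Within the data shown here, with no direct precedent, a middling, uncertain outcome is expected for compound 3, giving an estimated step of a 1.8-fold higher number from compound 2 to compound 3 (0.26 log units; within the scatter) in this assay. Compound 3 is therefore estimated at 15000 nM, with a range from 4000 nM to 60000 nM.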

Compound 3, concentration for 50% growth inhibition: 14300 nM
Estimate against measurement, compound 3: 1.0-fold (0.02 log units) above, and the stated range covers the measured number.
By their numbers in this assay, from the lowest: compounds 2 and 3 (each within the scatter of the next); then compound 1.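

In this assay the change from the chlorine-bearing ring of compound 2 to the plain ring with a methyl on the carbon with the double bond to nitrogen gives a 1.7-fold higher number from compound 2 to compound 3 (0.24 log units; within the scatter) and so stays inside the usual spread of repeats; in this pair, a ring chlorine is not needed to reach this level of growth inhibition. The same kind of exchange against the other chlorine-bearing compound gives a 2.9-fold lower number from compound 1 to compound 3 (0.47 log units; beyond the scatter) and thus leaves compound 1 apart from both compound 2 and compound 3, so the ring chlorine of compound 1 does not set a level that compound 3 shares. Nothing at hand explains these numbers, and since loss of chlorine and gain of methyl arrive together, their separate shares in either step cannot be read.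

Still open, as far as these compounds go, is how the plain ring behaves with a hydrogen on that carbon, and how a methyl there behaves alongside a ring chlorine. Also open, from the compounds shown here alone, is what a methoxy group on the ring or an ethyl group on that carbon would do to the number.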